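Benzyl substitution in a trimethoxyphenyl thioacetamide series

The compounds below may be only part of what the source reports. "The series", "measured", "known", "first", "only" and "open" are said of these compounds alone.

Compound 1, `COc1cc(N(Cc2ccccc2)C(=O)CSc2nc3ccccc3s2)cc(OC)c1OC`, gives 54500 nM in a functional assay on HCT-116 cells (Homo sapiens) for antiproliferative activity, read by MTT assay, with a stated time of 48 h; a lower number here means a stronger inhibitor, a higher number a weaker inhibitor. Compound 2, `COc1cc(N(Cc2ccc(C)cc2)C(=O)CSc2nc3ccccc3s2)cc(OC)c1OC`, gives only a limit, > 80000 nM. Compound 3, `COc1ccc(CN(C(=O)CSc2nc3cc(Cl)ccc3s2)c2cc(OC)c(OC)c(OC)c2)cc1O`, gives 429 nM.

Going by the values given here, compound 2 thus sits at the limit of > 80000 nM in this assay, at which 1 of the 3 values shown sits; the single measured step, an at least 1.4-fold higher number from compound 1 to compound 2 (0.16 log units; that floor lies within the scatter), is the only one recorded. Compound 4, `COc1ccc(CN(C(=O)CSc2nc3ccccc3s2)c2cc(OC)c(OC)c(OC)c2)cc1Br`, carries 3-bromo-4-methoxyphenyl in place of 4-methylphenyl on a saturated chain carbon bound to an amide-type nitrogen. Among the compounds with values here, no measured step covers this change, so the expectation rests on the values shown. Among the compounds that differ from compound 4 in two places, compound 3 gives 429 nM in this assay. Compound 2, by contrast, stands only at a limit of the assay. A sizeable drop in number is therefore expected for compound 4, estimated as an at least 16-fold lower number from compound 2 to compound 4 (1.20 log units; beyond the scatter). Compound 4 is expected to give about 5000 nM, within 500 nM to 50000 nM.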

Compound 4, half-maximal inhibitory concentration: 4550 nM
Compound 4: the middle estimate sits 1.1-fold (0.04 log units) above what was measured; low and high end bracket the measured number.
By their numbers in this assay, from the lowest: compound 3; then compound 4; then compound 1. At a limit, above all of these: compound 2.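

On the saturated chain carbon bound to an amide-type nitrogen, 3-bromo-4-methoxyphenyl in place of phenyl gives a 12-fold lower number from compound 1 to compound 4 (1.08 log units; beyond the scatter) in this assay, so a change at this position can reach well beyond the scatter, which the methyl step did not show. In place of 4-methylphenyl, the same group gives an at least 17-fold lower number from compound 2 to compound 4 (1.24 log units; beyond the scatter). Compound 2 stands only at a limit: the limit of > 80000 nM in this assay, at which 1 of the 4 values shown sits.

On these data alone, what the bromine and the methoxy each contribute on the otherwise unchanged core stays open. So does the effect on the number of an amine or a carboxylic acid on this ring.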